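Cycloheptyl in place of morpholin-4-yl: working notes

The source may hold more compounds than are shown below. What is called first, only, known or untested is meant among the compounds shown, and "the series" means these compounds.

Values measured in an ADME assay on MRC5 cells (Homo sapiens) for inhibition, with a stated time of 72 h (on this read-out lower numbers stand for an effect already at smaller amounts and higher numbers for an effect only at larger amounts of compound), so far:
compound 1 `COc1cccc(OC)c1C(=O)Nc1c[nH]nc1C(=O)NN1CCOCC1` gives > 50000 nM
compound 2 `CO[C@H]1CC[C@H](NC(=O)c2n[nH]cc2NC(=O)c2cc(Cl)cc(Cl)c2)CC1` gives 13000 nM
compound 3 `CO[C@H]1CC[C@H](NC(=O)c2n[nH]cc2NC(=O)c2ccc(N3CCCC3)cc2)CC1` gives > 50000 nM

Compound 1 has no numerical value on this read-out, only the limit > 50000 nM and nothing finer. Among the measured compounds shown here, compound 3 is likewise reported only as a limit, so the series so far shows the limit of > 50000 nM in this assay, at which 2 of the 3 values shown sit, and has one number. That number belongs to compound 2 (13000 nM).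

The next compound is compound 4 `COc1cccc(OC)c1C(=O)Nc1c[nH]nc1C(=O)NC1CCCCCC1` and it differs from compound 1 by one change, cycloheptyl in place of morpholin-4-yl on an amide-type nitrogen on the shared core. In words, it carries cycloheptyl in place of morpholin-4-yl on an amide-type nitrogen.

For the measured compounds named here, no measured pair differs in one place, so the size of this step cannot be read from the series. A modest move towards lower numbers is expected, since compound 2 at 13000 nM shows that values within range do occur here. Expected in this assay is an at least 1.6-fold lower number from compound 1 to compound 4 (0.22 log units; that floor lies within the scatter) and the result may again be only a limit. For compound 4 the estimated value is 30000 nM (expected range 9000 nM to 50000 nM)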

Compound 4, half-maximal effective concentration: 42000 nM
For compound 4 the middle estimate is 1.4-fold (0.15 log units) below the measured one; the range from low to high includes it.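

In this assay, the exchange of morpholin-4-yl for cycloheptyl on an amide-type nitrogen gives the shared core a numerical reading, with compound 4 at 42000 nM. Compound 1 is reported only as a limit of the assay, > 50000 nM. The only one-place step in the series is an at least 1.1-fold lower number from compound 1 to compound 4 (0.07 log units; that floor lies within the scatter), and it can be stated only as a floor because its starting point is a limit: the limit of > 50000 nM in this assay, at which 2 of the 4 values shown sit.

From the compounds shown here alone, the true size of the step stays open, and a floor within the scatter does not establish that this change moved the read-out at all. The change also replaces a six-membered non-aromatic ring with 2 hetero atoms by a seven-membered ring of carbon only in a single move, so ring size and the loss of the hetero atoms cannot be told apart here; cyclohexyl or piperidin-1-yl on the same amide-type nitrogen would be needed to separate the two.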